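Ester and side-ring variation in a cyclohexenyl dihydropyranone series

The source may report more compounds than this note shows. Statements on the series, on what has been measured and on what is new or still open speak of the compounds shown alone.

Compound 1 `CCCCC/C=C\C/C=C\C/C=C\C/C=C\CCCC(=O)OC[C@@H]1C=CC(=O)[C@@H](CC2=CCCCC2)O1` gives 35000 nM in a functional assay on LFCl2A cells (Rattus norvegicus) for cytotoxicity; on this read-out higher numbers stand for weaker inhibition and lower numbers for stronger inhibition. Compound 3 `CCCCC/C=C\C/C=C\C/C=C\C/C=C\CCCC(=O)OC[C@@H]1C=CC(=O)[C@@H](C2CCCC=C2C)O1` gives 5000 nM in this assay and carries the change (2-methylcyclohex-2-en-1-yl in place of (cyclohex-1-en-1-yl)methyl on a saturated ring carbon); the step of a 7.0-fold lower number from compound 1 to compound 3 (0.85 log units; beyond the scatter) is a modest gain. Compound 2 `CCCC(=O)OC[C@H]1O[C@H](CC2=CCCCC2)C=CC1=O` gives 90 nM in this assay; the difference between the core of compound 2 and that of compound 1 is not broken down here, and compound 2 stands lowest of the three numbers. Compound 4 `CCCC(=O)OC[C@H]1O[C@H](C2CCCC=C2C)C=CC1=O` is not yet measured; it differs from compound 2 by 2-methylcyclohex-2-en-1-yl in place of (cyclohex-1-en-1-yl)methyl on a saturated ring carbon, the same kind of change as from compound 1 to compound 3, the place here being two ring bonds from the ring atom that bears a ((propylcarbonyl)oxy)methyl group rather than a large group. A gain of about a 3.6-fold lower number from compound 2 to compound 4 (0.56 log units; beyond the scatter) is expected, smaller than that seen from compound 1 to compound 3, because compound 2 already gives 90 nM. The estimate for compound 4 is 25 nM, between 6 nM and 100 nM.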

Compound 4, half-maximal inhibitory concentration: 350 nM
Beside the measured number, compound 4's estimate is 14-fold (1.15 log units) below it, and the stated range ends below it.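

On the core of compound 2, 2-methylcyclohex-2-en-1-yl in place of (cyclohex-1-en-1-yl)methyl gives a 3.9-fold higher number from compound 2 to compound 4 (0.59 log units; beyond the scatter) in this assay. The same change moves the number in opposite directions on the two cores, so its effect does not carry from one core to the other in this series: the same change on two cores in this assay, a 7.0-fold lower number (0.85 log units; beyond the scatter) from compound 1 to compound 3 and a 3.9-fold higher number (0.59 log units; beyond the scatter) from compound 2 to compound 4, 27-fold (1.43 log units) apart, beyond the scatter of two such steps. Going by these compounds alone, these two pairs show only that the step depends on the core; they do not show which difference between the cores reverses it, and that difference is not broken down here.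

Open, going by these compounds, is how the change behaves on an octanoyl ester. Also open, on these data alone, is what a carboxylic acid or a primary amine gives in place of the ((propylcarbonyl)oxy)methyl group.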